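Moving the hydroxyl on one arm of the series

The source may hold more compounds than are shown below. What is called first, only, known or untested is meant among the compounds shown, and "the series" means these compounds.

Measured so far:
compound 1, `Oc1ccc(-c2cc(-c3ccsc3)cc(-c3cccc(O)c3)n2)cc1`, 760 nM
compound 2, `Oc1ccc(-c2cc(-c3ccsc3)cc(-c3ccc(O)cc3)n2)cc1`, 1770 nM
compound 3, `Oc1cccc(-c2cc(-c3ccoc3)cc(-c3ccccc3O)n2)c1`, > 50000 nM

In a functional assay on T47D cells (Homo sapiens) for cytotoxicity, read by CCK-8 assay (a lower number here means a stronger inhibitor, a higher number a weaker inhibitor), compound 1 gives 760 nM. Compound 2 differs from it by 4-hydroxyphenyl in place of 3-hydroxyphenyl on an aromatic carbon, and in this assay compound 2 gives 1770 nM, which is a 2.3-fold higher number from compound 1 to compound 2 (0.37 log units; beyond the scatter).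

Compound 3 carries a different core; how its core differs from that of compound 1 is not broken down here. For compound 3 the value in this assay is a limit of the assay and not a number: > 50000 nM, the same limit as the limit of > 50000 nM in this assay, at which 1 of the 3 values shown sits.

Compound 4, `Oc1ccc(-c2cc(-c3ccoc3)cc(-c3ccccc3O)n2)cc1`, is not yet measured. It differs from compound 3 by 4-hydroxyphenyl in place of 3-hydroxyphenyl on an aromatic carbon. This is the same kind of change as from compound 1 to compound 2, though the surroundings differ: in compound 3 the site is meta to a 2-hydroxyphenyl group and meta to a furan-3-yl group, whereas in compound 1 it is meta to a 4-hydroxyphenyl group and meta to a thiophen-3-yl group.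

Within the data shown here, since the only measured instance of this change gave a 2.3-fold higher number from compound 1 to compound 2 (0.37 log units; beyond the scatter), and compound 3 already sits at a limit, compound 4 is expected to remain at or past that limit, with an estimated step that the limit leaves unreadable from compound 3 to compound 4. The estimate for compound 4 in this assay is 100000 nM, expected to fall between 30000 nM and 400000 nM, most likely reported only as a limit.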

Compound 4, half-maximal inhibitory concentration: > 50000 nM
Compound 4: only a limit was reported; the forecaster's own chance of this, stated with the estimate: 85%; the middle value is on the limit's open side.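

No step can be read between compound 3 and compound 4 in this assay, because both are reported only as limits of the assay: the limit of > 50000 nM in this assay, at which 2 of the 4 values shown sit.

The compounds shown leave open whether 4-hydroxyphenyl in place of 3-hydroxyphenyl shifts the value on the core of compound 3 at all, as it does on the core of compound 1.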